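Ethoxy-triazole replacing amino-oxadiazole on the benzylic carbon

The source may hold more compounds than are shown below. What is called first, only, known or untested is meant among the compounds shown, and "the series" means these compounds.

Measured in a functional assay on the whole organism (strain NMRI) with Mus musculus as the target, with a stated time of 60 min, at a dose of 5 mg/kg by the intraperitoneal route; a higher number here means a stronger effect of the compound at the dose given, a lower number a weaker effect:
- compound 1 `CCSc1nnc(Cc2ccc(Cl)cc2Oc2ccccc2F)[nH]1` gives 126%
- compound 2 `Fc1ccccc1Oc1cc(Cl)ccc1Cc1nnc(SCc2ccccc2)[nH]1` gives 166%
- compound 3 `Nc1nnc(Cc2ccc(Cl)cc2Oc2ccccc2F)o1` gives 112%

Compound 3 stands lowest of the three in this assay, with compound 1 nearest and compound 2 furthest. Compound 4 `CCOc1nnc(Cc2ccc(Cl)cc2Oc2ccccc2F)[nH]1` is not yet measured; it differs from compound 3 by a group of 8 heavy atoms (4 carbon, 3 nitrogen, 1 oxygen; one five-membered aromatic ring with 3 hetero atoms) in place of a group of 6 heavy atoms (2 carbon, 3 nitrogen, 1 oxygen; one five-membered aromatic ring with 3 hetero atoms), on a saturated chain carbon bound to an aromatic carbon. Among the compounds with values here, the only measured step touching this position is a number 14 percentage points lower from compound 1 to compound 3 (beyond the scatter), where the amino-oxadiazole was the weaker partner. Compound 4 carries the same kind of ring as compound 1 with an oxygen-linked ethyl, so a step back upward is expected, of roughly the size seen in that pair. For compound 4 a value of 122% is expected, range 100% to 145%, meaning an expected step of a number 10 percentage points higher from compound 3 to compound 4 (within the scatter).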

Compound 4, a percentage reported as activity, at one dose (the size of the read-out at that dose, not a potency): 111%
Beside the measured number, compound 4's estimate is 11 percentage points above it; the measured number falls inside the stated range.
By their numbers in this assay, from the lowest: compounds 4 and 3 (each within the scatter of the next); then compound 1; then compound 2.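

In this assay, the oxygen link does not match the sulfur link: ethoxy in place of ethylsulfanyl gives a number 15 percentage points lower from compound 1 to compound 4 (beyond the scatter), and ethoxy in place of benzylsulfanyl gives a number 55 percentage points lower from compound 2 to compound 4 (beyond the scatter). The exchange of the 5-amino-1,3,4-oxadiazol-2-yl group for the ethoxy-bearing group on the saturated chain carbon gives a number 1 percentage points lower from compound 3 to compound 4 (within the scatter), so this pair shows no separation. Nothing measured here accounts for the gap between the sulfur and oxygen links.

Going by these compounds, whether benzyloxy in place of ethoxy would bring a rise like that seen on sulfur stays open, as does the effect of a longer chain on the sulfur.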